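A Methoxy Added to the Tetrazole Compound

A few compounds are considered here, and "the series" means these few. Any claim that something is new, unique, unknown or untested is made for them only; others in the source may bear on it.

Compound 1 `O=C(O)c1ccc(COc2cccc(OCc3ccc4ccccc4n3)c2)cc1` in a functional assay (lung) for inhibition, with Cavia porcellus as the target (on this read-out higher numbers stand for weaker inhibition and lower numbers for stronger inhibition), gives 75 nM
Compound 2 `c1cc(OCc2ccc(-c3nn[nH]n3)cc2)cc(OCc2ccc3ccccc3n2)c1` in this assay gives 12 nM

Compound 2 has the lower of the two numbers, making it the stronger inhibitor so far. Compound 3 `COc1cc(-c2nn[nH]n2)ccc1COc1cccc(OCc2ccc3ccccc3n2)c1` differs from it by one change: methoxy in place of hydrogen on an aromatic carbon. Among the compounds with values here, the only measured step is a 6.3-fold lower number from compound 1 to compound 2 (0.80 log units; beyond the scatter), which replaced carboxy with 2H-tetrazol-5-yl and shows nothing about methoxy. No step beyond the scatter is therefore expected in this assay, in either direction, although the uncertainty is wide. The estimated step is no change at the digits printed from compound 2 to compound 3 (within the scatter). The expected value for compound 3 is 12 nM, with an estimated range of 4 nM to 40 nM.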

Compound 3, half-maximal inhibitory concentration: 9 nM
For compound 3 the middle estimate is 1.3-fold (0.12 log units) above the measured one; low and high end bracket the measured number.
By their numbers in this assay, from the lowest: compounds 3 and 2 (each within the scatter of the next); then compound 1.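

In this assay, methoxy in place of hydrogen, ortho to a large group and meta to a 2H-tetrazol-5-yl group, gives a 1.3-fold lower number from compound 2 to compound 3 (0.12 log units; within the scatter), so the two compounds cannot be told apart. Within the data shown here, the earlier step concerned only carboxy and 2H-tetrazol-5-yl, so only this step speaks to a group added at this position. Nothing available here offers an explanation for this result.

From the compounds shown here alone, whether an amine, a fluorine atom or a longer chain such as butoxy at this position would also stay within the scatter remains open.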